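The source may report more compounds than this note shows. Statements on the series, on what has been measured and on what is new or still open speak of the compounds shown alone.

Measured compounds in the series:

compound 1 `Cn1c(-c2ccc(NC(=O)CN3CCN(Cc4ccccc4)CC3)cc2)nc(-c2ccccc2)c1-c1ccccc1` — 65.5 ug/mL
compound 2 `COc1ccc(CN2CCN(CC(=O)Nc3ccc(-c4nc(-c5ccccc5)c(-c5ccccc5)n4C)cc3)CC2)cc1` — 77.3 ug/mL

Among the compounds with values here, in a functional assay on HT-29 cells (Homo sapiens) for cytotoxicity, read by MTT assay, with a stated time of 24 h (a higher number here means a weaker inhibitor, a lower number a stronger inhibitor), compound 2 gives 77.3 ug/mL, the highest of the two numbers so far; its nearest neighbour is compound 1, and the step of a 1.2-fold higher number from compound 1 to compound 2 (0.07 log units; within the scatter) lies within the scatter.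

Compound 3 `Cn1c(-c2ccc(NC(=O)CN3CCN(Cc4ccc(Cl)cc4)CC3)cc2)nc(-c2ccccc2)c1-c1ccccc1` has not been measured in this assay. It differs from compound 2 by chloro in place of methoxy on an aromatic carbon. Within the data shown here, the only measured step that bears on this position is a 1.2-fold higher number from compound 1 to compound 2 (0.07 log units; within the scatter), which did not move the number beyond the scatter; no pair of measured compounds carries a chloro here, so the size of the new change can only be guessed from that single step. No step beyond the scatter is expected, in either direction. Compound 3 is therefore estimated at 70 ug/mL, between 38 ug/mL and 130 ug/mL, the expected step being a 1.1-fold lower number from compound 2 to compound 3 (0.04 log units; within the scatter).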

Compound 3, half-maximal inhibitory concentration: 12 ug/mL
Beside the measured number, compound 3's estimate is 5.8-fold (0.77 log units) above it; the measured number lies below the stated range.
By their numbers in this assay, from the lowest: compound 3; then compounds 1 and 2 (each within the scatter of the next).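

In this assay the position on the benzyl ring, para to a large group, turns out to be able to move the number: the change from 4-methoxybenzyl to 4-chlorobenzyl gives a 6.4-fold lower number from compound 2 to compound 3 (0.81 log units; beyond the scatter) and chloro in place of hydrogen gives a 5.5-fold lower number from compound 1 to compound 3 (0.74 log units; beyond the scatter) on the same core. Hydrogen and methoxy at this place, in compound 1 and compound 2, stay within the scatter of each other, so among the three groups shown only chloro separates from the others. Nothing at hand accounts for this difference.

From the compounds shown here alone, whether fluoro, bromo or trifluoromethyl at the same place would follow chloro or stay with hydrogen and methoxy remains open, as does the outcome with an amine or a carboxylic acid there. Going by these compounds, whether the step carries over to other cell types also stays open.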